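Stereochemical variation in a piperidine-type series

The source may hold more compounds than are shown below. What is called first, only, known or untested is meant among the compounds shown, and "the series" means these compounds.

Measured compounds:
compound 1 `O=C(O)[C@H]1NCC=C[C@@H]1O`, 60%
compound 2 `O=C(O)[C@H]1NCC=C[C@H]1O`, 17%
compound 3 `O=C(O)[C@@H]1NC[C@H](O)[C@H](O)[C@H]1O`, 39%

In an assay on isolated protein for inhibition of cytosolic endo-beta-N-acetylglucosaminidase (Homo sapiens), tested at 1000 uM (on this read-out higher numbers stand for more inhibition at the one concentration tested (going by the name of the read-out) and lower numbers for less inhibition), compound 2 stands lowest of the three numbers; the nearest is compound 3, which gives 39%, and the furthest is compound 1, which gives 60%. Going by the values given here, the only measured stereochemical step is a number 43 percentage points lower from compound 1 to compound 2 (beyond the scatter), which rests on (the fact that compounds 1 and 2 differ only in the configuration as drawn); it shows that a single inversion at a saturated ring carbon can move this assay by a large amount.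

Compound 4 `O=C(O)[C@@H]1NCC=C[C@@H]1O` is now to be measured. It differs from compound 2 as follows: the two compounds have the same atoms and bonds and differ only in configuration as drawn: 2 of 2 stereo elements differ (all stereocentres are inverted: mirror images); a stereocentre at a saturated ring carbon is drawn S in compound 2 and R in compound 4; a stereocentre at a saturated ring carbon is drawn R in compound 2 and S in compound 4. Among the compounds with values here, no mirror-image pair has been measured, so the single-inversion step gives the size scale but not the direction for a double inversion. Since compound 2 already sits at the bottom, a further large drop has little room, and a rise is at least as plausible.

Compound 4 is therefore expected to give about 35%, with a wide range from 5% to 75%, meaning an expected step of a number 18 percentage points higher from compound 2 to compound 4 (beyond the scatter).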

Compound 4, a percentage reported as inhibition, at one concentration (the size of the read-out at that concentration, not a potency): 14%
Compound 4: the middle estimate sits 21 percentage points above what was measured; the range from low to high includes it.
By their numbers in this assay, from the lowest: compounds 4 and 2 (each within the scatter of the next); then compound 3; then compound 1.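

In this assay, a number 46 percentage points lower from compound 1 to compound 4 (beyond the scatter), so inverting the other stereocentre of compound 1 also carries a large step, and the earlier drop is not tied to a single centre: the fact that compounds 1 and 4 differ only in the configuration as drawn. Inverting both centres gives a number 3 percentage points lower from compound 2 to compound 4 (within the scatter), so this assay does not separate this mirror-image pair: the fact that compounds 2 and 4 differ only in the configuration as drawn. Going by these compounds alone, of the three configurations now seen on this shared core, only that of compound 1 stands clear, as either single inversion leads to values that cannot be told apart.

From the compounds shown here alone, what the mirror image of compound 1 would give remains open, and with it whether the configuration of compound 1 is the only one that stands clear. Also open, going by these compounds, is whether that configuration keeps its lead when a primary amide replaces the carboxylic acid.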